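The source may hold more compounds than are shown below. What is called first, only, known or untested is meant among the compounds shown, and "the series" means these compounds.

Three measured compounds share one core and differ in the group on a saturated ring carbon and in the substituent on the sulfonyl-bearing phenyl ring. In a functional assay on MCF7 cells (Homo sapiens) for cytotoxicity, read by sulforhodamine B assay, with a stated time of 3 days (a higher number here means a weaker inhibitor, a lower number a stronger inhibitor), compound 1 `O=c1cc[nH]c(=O)n1C1CN(S(=O)(=O)c2ccccc2[N+](=O)[O-])c2ccccc2CO1` gives 50900 nM. Compound 2 `O=[N+]([O-])c1ccccc1S(=O)(=O)N1CC(n2cnc3c(Br)ncnc32)OCc2ccccc21` gives 3620 nM in this assay, and the change from compound 1 to compound 2 brings a 14-fold lower number from compound 1 to compound 2 (1.15 log units; beyond the scatter). Compound 3 `Nc1ccccc1S(=O)(=O)N1CC(n2cnc3c(Cl)nc(Cl)nc32)OCc2ccccc21`, carrying a (2-aminophenyl)sulfonyl group, gives 820 nM, the lowest of the three numbers, beyond the scatter from compound 2 and further still from compound 1.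

Compound 4 `O=S(=O)(c1ccccc1NO)N1CC(n2cnc3c(Cl)nc(Cl)nc32)OCc2ccccc21` differs from compound 3 in one place: hydroxy in place of hydrogen on a nitrogen on an aromatic ring. For the measured compounds named here, no measured step touches this nitrogen. Going by the values given here, the only step on record concerns the group on the saturated ring carbon, and compound 2 and compound 3 differ in two places at once, so their two values alone cannot separate what the amino group contributes. With nothing bearing on the change, a step within the scatter is expected, a 1.2-fold higher number from compound 3 to compound 4 (0.09 log units; within the scatter). Compound 4 is therefore estimated at 1000 nM, with a range from 400 nM to 3000 nM.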

Compound 4, half-maximal inhibitory concentration: 1530 nM
Beside the measured number, compound 4's estimate is 1.5-fold (0.18 log units) below it; the range from low to high includes it.
By their numbers in this assay, from the lowest: compounds 3 and 4 (each within the scatter of the next); then compound 2; then compound 1.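

In this assay, for the compounds shown here, the first measured change on this nitrogen, amino to hydroxyamino, gives a 1.9-fold higher number from compound 3 to compound 4 (0.27 log units; within the scatter). Going by these compounds alone, on this core, with the group on the saturated ring carbon held the same, adding hydroxy to the nitrogen on the aromatic ring therefore leaves the cytotoxicity reading within the usual scatter, whereas the one earlier step, at the saturated ring carbon, lay well beyond it. Nothing measured here gives a reason for this result.

As far as these compounds go, whether larger groups on this nitrogen, such as methylamino or an acetamide, would also stay within the scatter remains open. So does what the nitrogen contributes at all, as the compounds shown include no match for compound 3 with a plain phenyl ring in place of the 2-aminophenyl group.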